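Halogen exchange on the phenyl core of a calpain inhibitor

The compounds below may be only part of what the source reports. "The series", "measured", "known", "first", "only" and "open" are said of these compounds alone.

compound 1: `O=C(O)/C(S)=C/c1ccccc1Cl` — 20700 nM
compound 2: `O=C(O)/C(S)=C/c1c[nH]c2c(F)cccc12` — 110 nM
compound 3: `O=C(O)/C(S)=C/c1c[nH]c2ccc(I)cc12` — 90 nM

Of the compounds shown here, three have been measured in an assay on isolated protein for inhibition of Calpain-1 catalytic subunit (Sus scrofa); on this read-out higher numbers stand for weaker inhibition and lower numbers for stronger inhibition. Compound 1 gives 20700 nM and stands at the highest number of the three, far beyond the scatter from both compound 2, which gives 110 nM, and compound 3, which gives 90 nM. Compound 2 and compound 3 carry a different core from compound 1, so their numbers say nothing direct about what a change on the phenyl core of compound 1 will do.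

The step under consideration leads from compound 1 to compound 4, `O=C(O)/C(S)=C/c1ccccc1I`. The change is iodo in place of chloro on an aromatic carbon. Within the data shown here, no pair of measured compounds differs only in this way, so the size of the step has to be guessed. The account expects only a small step in this assay, if any, from compound 1 to compound 4, perhaps toward a lower number, but not clearly beyond the scatter: a 1.7-fold lower number from compound 1 to compound 4 (0.24 log units; within the scatter) is the estimated shift. For compound 4 the estimated value in this assay is 12000 nM, with a range from 4000 nM to 40000 nM.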

Compound 4, half-maximal inhibitory concentration: 42800 nM
For compound 4 the middle estimate is 3.6-fold (0.55 log units) below the measured one, and the stated range ends below it.
By their numbers in this assay, from the lowest: compounds 3 and 2 (each within the scatter of the next); then compound 1; then compound 4.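

In this assay, iodo in place of chloro on an aromatic carbon, ortho to a group of 6 heavy atoms, gives a 2.1-fold higher number from compound 1 to compound 4 (0.32 log units; beyond the scatter), so the exchange of one halogen for another at this position does register, and here it goes toward weaker inhibition. Compound 2 and compound 3 could not show this, since each differs from compound 1 in more than one place. Nothing at hand accounts for the direction of this modest step.

As far as these compounds go, whether fluoro, bromo, an amine or a carboxylic acid in this same place would move the number from that of compound 1, and in which direction, stays open. From the compounds shown here alone, it is also open whether iodo in place of chloro would give a step of similar size on the core of compound 2 or compound 3.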